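From a Branched Chain to a Methylated Aryl Amide

A few compounds are considered here, and "the series" means these few. Any claim that something is new, unique, unknown or untested is made for them only; others in the source may bear on it.

Of the compounds shown here, three built on one shared core have been measured in an assay on LtK cells with ATP-sensitive inward rectifier potassium channel 11 (Homo sapiens) as the target; on this read-out lower numbers stand for an effect already at smaller amounts and higher numbers for an effect only at larger amounts of compound. Compound 1 `CCC(C)C(=O)Nc1c(C(O)(C(F)(F)F)C(F)(F)F)ccc2ccccc12` carries a sec-butyl group on the carbonyl carbon of its amide and gives 177000 nM, the highest of the three numbers and therefore the weakest of the group. Compound 2 `Cc1ccccc1C(=O)Nc1c(C(O)(C(F)(F)F)C(F)(F)F)ccc2ccccc12` gives 5550 nM, and compound 3 `O=C(Nc1c(C(O)(C(F)(F)F)C(F)(F)F)ccc2ccccc12)c1cccc(Cl)c1` gives 98 nM. Replacing the branched chain with an aromatic ring brought a 32-fold lower number from compound 1 to compound 2 (1.50 log units; beyond the scatter) and a 1800-fold lower number from compound 1 to compound 3 (3.26 log units; beyond the scatter), and the two aromatic groups themselves are separated by a 57-fold lower number from compound 2 to compound 3 (1.75 log units; beyond the scatter).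

Compound 4 `Cc1cccc(C(=O)Nc2c(C(O)(C(F)(F)F)C(F)(F)F)ccc3ccccc23)c1` is the next step away from compound 1: 3-methylphenyl in place of sec-butyl on a carbonyl carbon. Both earlier aryl replacements bear on this change, and both lowered the number by a large amount. The 3-methylphenyl group of compound 4 is closer in name to the 3-chlorophenyl of compound 3 than to the 2-methylphenyl of compound 2, so the larger of the two earlier steps seems the better guide, tempered by the smaller one. A large drop in this assay is therefore expected, roughly a 590-fold lower number from compound 1 to compound 4 (2.77 log units; beyond the scatter). For compound 4 the estimated value is 300 nM, with a range from 60 nM to 1500 nM.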

Compound 4, half-maximal effective concentration: 23 nM
Compound 4: middle estimate off by 13-fold (1.12 log units), on the high side; the whole stated range lies above it.
By their numbers in this assay, from the lowest: compound 4; then compound 3; then compound 2; then compound 1.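

In this assay, the 3-methylphenyl group gives a 7700-fold lower number from compound 1 to compound 4 (3.89 log units; beyond the scatter), the largest drop yet seen on replacing sec-butyl on the carbonyl carbon, and compound 4 now has the lowest number of the four. The earlier compounds shown here left open whether the gap between the two aryl groups came from the methyl or from where it sits, and a 240-fold lower number from compound 2 to compound 4 (2.38 log units; beyond the scatter) answers this: 2-methylphenyl and 3-methylphenyl differ only in where the methyl sits on the ring, yet their numbers lie far apart. By contrast, methyl in place of chloro on an aromatic carbon gives only a 4.3-fold lower number from compound 3 to compound 4 (0.63 log units; beyond the scatter), so in this small set, changing where the methyl sits moves the number much more than exchanging chloro for methyl. Nothing available explains why these changes have the effects they do.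

As far as these compounds go, how a plain phenyl group without any added atom would compare with these aryl groups remains open. From the compounds shown here alone, it is also open whether a methoxy, a nitrile or an amine on the ring would follow methyl and chloro, or would instead move the number in another direction.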